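The source may hold more compounds than are shown below. What is called first, only, known or untested is meant among the compounds shown, and "the series" means these compounds.

In a functional assay on HL-60 cells (Homo sapiens) for antiproliferative activity, with a stated time of 24 h (a lower number here means a stronger inhibitor, a higher number a weaker inhibitor), three compounds that share one core have been measured. Compound 1 `NC(=O)c1c(NC(=O)c2ccccc2Cl)sc2c1CCN(Cc1ccccc1F)C2` gives 21800 nM, compound 2 `NC(=O)c1c(NC(=O)c2ccccc2Cl)sc2c1CCN(Cc1ccc([N+](=O)[O-])cc1)C2` gives 11400 nM, and compound 3 `NC(=O)c1c(NC(=O)c2ccccc2Cl)sc2c1CCN(Cc1ccc(Cl)cc1Cl)C2` gives 8010 nM. Compound 3 thus holds the lowest of the three numbers, yet compound 2 lies within the scatter of it, so the two cannot be told apart; only compound 1 stands clearly apart, through the step of a 2.7-fold lower number from compound 1 to compound 3 (0.43 log units; beyond the scatter). The remaining steps, a 1.9-fold lower number from compound 1 to compound 2 (0.28 log units; within the scatter) and a 1.4-fold lower number from compound 2 to compound 3 (0.15 log units; within the scatter), stay within the scatter.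

Compound 4 `NC(=O)c1c(NC(=O)c2ccccc2Cl)sc2c1CCN(C(=S)Nc1ccccc1F)C2` has not yet been measured. It differs from compound 3 in one place: a group of 10 heavy atoms (7 carbon, 1 nitrogen, 1 fluorine, 1 sulfur; one six-membered aromatic ring of carbon only) in place of a group of 9 heavy atoms (7 carbon, 2 chlorine; one six-membered aromatic ring of carbon only), on an amine nitrogen in a ring. The entering group carries 2-fluorophenyl, which compound 1 also bears, but here it is joined to the ring nitrogen through a different linker. Within the data shown here, all three measured steps exchanged one benzyl group for another on that same nitrogen; none touched the linker itself, so no measured step speaks directly to this change. Because compound 1, which bears 2-fluorophenyl, gives 21800 nM, compound 4 is expected to move back toward that higher number, an expected step of a 1.9-fold higher number from compound 3 to compound 4 (0.27 log units; within the scatter). The estimate for compound 4 in this assay is 15000 nM, with a range from 5000 nM to 45000 nM.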

Compound 4, half-maximal inhibitory concentration: 4970 nM
Beside the measured number, compound 4's estimate is 3.0-fold (0.48 log units) above it; measured number below the stated range.
By their numbers in this assay, from the lowest: compounds 4, 3, 2 and 1 (each within the scatter of the next, the first and the last beyond it).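

In this assay, the amine nitrogen in a ring accepts a change of the linker itself, not only of the benzyl group on it: the sulfur-bearing linker with its hydrogen-bond donor leaves the number in the range of the 2,4-dichlorobenzyl compound (a 1.6-fold lower number from compound 3 to compound 4 (0.21 log units; within the scatter)) and also gives a clear step from the 4-nitrobenzyl compound (a 2.3-fold lower number from compound 2 to compound 4 (0.36 log units; beyond the scatter)). The most telling comparison is with compound 1, which carries the same 2-fluorophenyl on a plain benzyl link (a 4.4-fold lower number from compound 1 to compound 4 (0.64 log units; beyond the scatter)), so 2-fluorophenyl does not fix the number by itself, and the two compounds bearing it sit at the two ends of the series. No measurement at hand explains this shift.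

On these data alone, it stays open whether the sulfur matters, which a urea with oxygen in its place would test, and whether a shorter amide link would hold the number. Equally open, as far as these compounds go, is whether 2,4-dichlorophenyl or 4-nitrophenyl on this same linker would go further than 2-fluorophenyl does.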